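Removing the Phenol Hydroxy from a Weak Antiproliferative Indanone

A few compounds are considered here, and "the series" means these few. Any claim that something is new, unique, unknown or untested is made for them only; others in the source may bear on it.

The series comprises three measured compounds and one awaiting measurement. In a functional assay on PC-3 cells (Homo sapiens) for antiproliferative activity, read by MTT assay, with a stated time of 48 h (on this read-out higher numbers stand for weaker inhibition of growth and lower numbers for stronger inhibition of growth), compound 1 `COc1cc(/C=C2\Cc3c(cc(OC)c(OC)c3OC)C2=O)cc(OC)c1OC` gives 4990 nM. Compound 2 `COc1cc2c(c(OC)c1OC)C/C(=C\c1cc(OC)c(OC)c(OC)c1OC)C2=O` reaches only a limit of this assay, > 10000 nM. Among the measured compounds shown here, the one measured step, an at least 2.0-fold higher number from compound 1 to compound 2 (0.30 log units; that floor lies within the scatter), therefore cannot be given an exact size. Compound 3 `COc1ccc(/C=C2\Cc3cc(OC)c(OC)c(OC)c3C2=O)cc1O` also reaches only a limit, > 10000 nM. On the numbers shown, compound 3 thus stands at the floor of this assay, where two of the three values sit, as the limit of > 10000 nM in this assay, at which 2 of the 3 values shown sit, records, and no number is known for it. Compound 4 `COc1ccc(/C=C2\Cc3cc(OC)c(OC)c(OC)c3C2=O)cc1` differs from compound 3 by hydrogen in place of hydroxy on an aromatic carbon. For the measured compounds named here, no measured step concerns the loss of a hydroxy; the single measured step, from compound 1 to compound 2, concerns a methoxy entering, so it bears on this change only in showing that substituent changes on that ring did not bring the numbers down. Compound 4 is therefore expected to stay near the floor, at 15000 nM, within 3000 nM to 60000 nM. The step that the limit leaves unreadable from compound 3 to compound 4 is expected to lie within the scatter, with a fair chance that compound 4 again yields only a limit.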

Compound 4, concentration for 50% growth inhibition: > 10000 nM
Compound 4: only a limit was reported; the forecaster's own chance of this, stated with the estimate: 60%; the middle value does not contradict the limit.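

In this assay compound 4 gives > 10000 nM, which is a limit. Among the compounds shown here, compound 3 also stands at a limit, so no step between compound 3 and compound 4 can be read. Whether hydrogen in place of hydroxy changes growth inhibition at all stays open, with only a limit to go on: the limit of > 10000 nM in this assay, at which 3 of the 4 values shown sit.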